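Trifluoromethyl for methyl: working notes toward compound 3

This account rests on a few compounds, and the source may have more. Where it says the series, first, only, none or still open, it means among the compounds named here.

Measured so far:
compound 1, `Cc1ccc(-c2cnc(N)nc2-c2ccccc2)cc1`: 51%
compound 2, `Nc1ncc(-c2cccc(F)c2)c(-c2ccccc2)n1`: 63%

In an assay on CHO cells for displacement of a labelled ligand from adenosine receptor A1 (Homo sapiens), read by scintillation counting, with a stated time of 1 h, tested at 1 uM (a higher number here means more inhibition at the concentration tested (going by the name of the read-out), a lower number less inhibition), compound 1 gives 51%, the lowest of the two numbers seen. The nearest number is that of compound 2, which gives 63% in this assay, a value higher by more than the usual scatter. Compound 2 differs from compound 1 in more than one place, so its gap to compound 1 shows only what the two values show and is not a single step.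

Compound 3 is `Nc1ncc(-c2ccc(C(F)(F)F)cc2)c(-c2ccccc2)n1`. Against compound 1 it shows (trifluoromethyl in place of methyl on an aromatic carbon). Among the measured compounds shown here, no measured pair carries that change, so nothing here anchors its size. The step of a number 1 percentage points lower from compound 1 to compound 3 (within the scatter) is expected to be small and to fall within the scatter, in no firm direction. For compound 3 the estimated inhibition in this assay is 50%, with a range from 30% to 70%.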

Compound 3, a percentage reported as inhibition, at one concentration (the size of the read-out at that concentration, not a potency): 51%
Compound 3: middle estimate off by 1 percentage points, on the low side; the measured number falls inside the stated range.
By their numbers in this assay, from the lowest: compounds 1 and 3 (each within the scatter of the next); then compound 2.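

On the aromatic carbon para to a large group, trifluoromethyl in place of methyl is the only single-place step shown in this series, and in this assay it reads no change at the digits printed from compound 1 to compound 3 (within the scatter) and so gives this position its first anchor. At this position, the two groups cannot be told apart at the single concentration tested, although that reading is not a potency. No supporting data on any property of these compounds bear on this result.

Still open, on these data alone, is whether an amine or a carboxylic acid on the same aromatic carbon would move the number beyond the scatter. Also open, as far as these compounds go, is whether the same change would read alike elsewhere on the shared core, or whether potency values would separate compound 1 and compound 3.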